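The source may hold more compounds than are shown below. What is called first, only, known or untested is meant among the compounds shown, and "the series" means these compounds.

Among the compounds with values here, compound 1 `N#Cc1ccc(-c2csc(N3N=C(c4ccc(Cl)s4)CC3c3ccc(F)cc3)n2)cc1` is one of three compounds measured in an ADME assay on NIH3T3 cells (Mus musculus) for cytotoxicity, read by XTT assay, with a stated time of 24 h; on this read-out higher numbers stand for weaker inhibition and lower numbers for stronger inhibition. In this assay compound 1 gives only a limit, > 500 ug/mL, not a number. Compound 2 `Cc1ccc(C2=NN(c3nc(-c4ccc(C(F)(F)F)cc4)cs3)C(c3ccc(F)cc3)C2)s1` likewise gives only a limit in this assay, > 500 ug/mL. Compound 3 `Cc1ccc(C2=NN(c3nc(-c4ccc(C#N)cc4)cs3)C(c3ccc(F)cc3)C2)s1` gives 250 ug/mL in this assay. The two steps that join them are an at least 2.0-fold lower number from compound 1 to compound 3 (0.30 log units; that floor lies within the scatter) and an at least 2.0-fold lower number from compound 2 to compound 3 (0.30 log units; that floor lies within the scatter), and both rest on (the limit of > 500 ug/mL in this assay, at which 2 of the 3 values shown sit), so neither step carries a size that stands clear of the scatter.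

Compound 4 `COc1ccc(-c2csc(N3N=C(c4ccc(Cl)s4)CC3c3ccc(F)cc3)n2)cc1` differs from compound 1 by methoxy in place of cyano on an aromatic carbon. Within the data shown here, no measured step touches this change: the known steps alter the other aromatic ring of the core, or swap a cyano for a trifluoromethyl, and all stay within the scatter or sit at a limit. The expected step is therefore none beyond the scatter in this assay, so compound 4 is expected to give 500 ug/mL, within a range from 200 ug/mL to 900 ug/mL, and the step from compound 1 is estimated as a number no higher from compound 1 to compound 4 (the limit leaves the size open).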

Compound 4, half-maximal inhibitory concentration: 103 ug/mL
Estimate against measurement, compound 4: 4.9-fold (0.69 log units) above; measured number below the stated range.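

Swapping the cyano of compound 1 for methoxy gives an at least 4.8-fold lower number from compound 1 to compound 4 (0.68 log units; beyond the scatter), so a change at this position, para to a large group, can move the number in this assay by more than the scatter, which the earlier cyano and trifluoromethyl pair, with a floor inside the scatter, did not show. Compound 1 gives > 500 ug/mL, which is a limit and not a number. The step from it is therefore a floor whose full size stays unknown: the limit of > 500 ug/mL in this assay, at which 2 of the 4 values shown sit.

On these data alone, whether methoxy in place of cyano acts the same way on the methyl-bearing compound 3 remains open. The compounds shown also leave open how an amine or a carboxylic acid at this position would read, and whether a longer chain than methoxy would go further.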